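The source may report more compounds than this note shows. Statements on the series, on what has been measured and on what is new or still open speak of the compounds shown alone.

Working notes on a set of four compounds tested in an assay on microsomes from brain for inhibition of Fatty-acid amide hydrolase 1 (Rattus norvegicus), read by fluorescence and HPLC, with a stated time of 60 min; on this read-out lower numbers stand for stronger inhibition and higher numbers for weaker inhibition. Compound 1 `CCCCCCCCc1ccc(OCC(=O)Cn2nnc(-c3ccc(S(=O)(=O)N(C)C)cc3)n2)cc1` gives 590 nM in this assay. Compound 2 `CCCCCCCCc1ccc(OCC(=O)Cn2nnc(-c3cccc(S(=O)(=O)N(C)C)c3)n2)cc1` gives 420 nM in this assay. The change from compound 1 to compound 2 is 3-(dimethylsulfamoyl)phenyl in place of 4-(dimethylsulfamoyl)phenyl on an aromatic carbon and its step is a 1.4-fold lower number from compound 1 to compound 2 (0.15 log units; within the scatter). Compound 3 `CCCCCCCCc1ccc(OCC(=O)Cn2nnnc2-c2ccc(S(=O)(=O)N(C)C)cc2)cc1` gives 1400 nM in this assay, the highest of the three numbers, with gaps to compound 1 and compound 2 that are beyond the scatter. The difference between the core of compound 1 and the core of compound 3 is not broken down here. Compound 4 `CCCCCCCCc1ccc(OCC(=O)Cn2nnnc2-c2cccc(S(=O)(=O)N(C)C)c2)cc1` has not yet been measured in this assay. Against compound 3 its change is 3-(dimethylsulfamoyl)phenyl in place of 4-(dimethylsulfamoyl)phenyl on an aromatic carbon. The place differs from that of the earlier change: in compound 3 the aromatic carbon is next to the ring atom that bears a large group, whereas in compound 1 it is two ring bonds from the ring atom that bears a large group; in both it is two ring bonds from the ring nitrogen. This is therefore the same kind of change, not the same change. For compound 4 a step of similar size is expected, a 1.4-fold lower number from compound 3 to compound 4 (0.15 log units; within the scatter), because the earlier step of a 1.4-fold lower number from compound 1 to compound 2 (0.15 log units; within the scatter) lay within the scatter. Compound 4 is estimated at 1000 nM in this assay, with a range from 500 nM to 2000 nM.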

Compound 4, half-maximal inhibitory concentration: 1900 nM
Beside the measured number, compound 4's estimate is 1.9-fold (0.28 log units) below it; the range from low to high includes it.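

In this assay, exchanging 4-(dimethylsulfamoyl)phenyl for 3-(dimethylsulfamoyl)phenyl on the core of compound 3 gives a step that does not separate the two compounds (a 1.4-fold higher number from compound 3 to compound 4 (0.13 log units; within the scatter)). Set beside the earlier step, this gives no sign that the change behaves differently on the two cores: (the same change on two cores in this assay, a 1.4-fold lower number (0.15 log units; within the scatter) from compound 1 to compound 2 and a 1.4-fold higher number (0.13 log units; within the scatter) from compound 3 to compound 4, 1.9-fold (0.28 log units) apart, within the scatter of two such steps). In these two pairs, the change therefore carries from one core to the other as a step too small to read, and the opposite directions of the two steps carry no meaning; this does not show that the two attachment patterns are equivalent on any other core, since two small steps at two different places on the ring are all the evidence there is, and it says nothing about a change large enough to be followed from core to core.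

The compounds shown leave open whether the same indifference holds when a carboxylic acid or a primary sulfonamide stands in place of the dimethylsulfamoyl group. They also leave open whether it survives on a core with a shorter chain in place of the octyl chain, and what separates the core of compound 1 from the core of compound 3 remains unresolved.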